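The source may hold more compounds than are shown below. What is called first, only, known or untested is meant among the compounds shown, and "the series" means these compounds.

Compound 1 `Cc1ccc(S(=O)(=O)N[C@@H](CC(=O)NC(C)(C)C)C(=O)NCCNS(=O)(=O)c2ccccc2)cc1`: in an ADME assay on Karpas-1106P cells (Homo sapiens) for cytotoxicity (on this read-out lower numbers stand for an effect already at smaller amounts and higher numbers for an effect only at larger amounts of compound), compound 1 reaches only the assay limit, > 11100 nM.
Compound 2 `Cc1ccc(S(=O)(=O)N[C@@H](CC(=O)NC(C)(C)C)C(=O)NCCNC(=O)Nc2ccccc2)cc1`: compound 2 likewise reaches only the limit, > 11100 nM.
Compound 3 `COc1cc(OC)cc(C(=O)NCCNC(=O)[C@H](CC(=O)NC(C)(C)C)NS(=O)(=O)c2ccc(C)cc2)c1`: compound 3 likewise reaches only the limit, > 11100 nM.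

Compound 2 stands where every other value shown stands, at the limit (the limit of > 11100 nM in this assay, at which 3 of the 3 values shown sit), with no number of its own. The step to compound 4 `Cc1ccc(S(=O)(=O)N[C@@H](CC(=O)NC(C)(C)C)C(=O)NCCNC(=O)c2ccccc2O)cc1` is 2-hydroxyphenyl in place of anilino on a carbonyl carbon. The nearest measured step, a step that the two limits leave unreadable from compound 2 to compound 3, is bracketed by two limits and gives no size. The same holds for a step that the two limits leave unreadable from compound 1 to compound 2 and for a step that the two limits leave unreadable from compound 1 to compound 3. With every value in the series sitting at the limit, no step beyond the scatter in either direction is expected for compound 4 in this assay. The expected step from compound 2 is a step that the limit leaves unreadable from compound 2 to compound 4. For compound 4 the estimated value in this assay is 20000 nM, in a range of 8000 nM to 50000 nM, most likely reported again only as a limit.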

Compound 4, half-maximal effective concentration: > 11100 nM
Compound 4: no number, only a limit; the forecaster's own chance of this, stated with the estimate: 85%; the middle value lies beyond the limit too.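

Compound 4 gives no readable step against compound 1, compound 2 or compound 3, because all four values are limits: the limit of > 11100 nM in this assay, at which 4 of the 4 values shown sit.

The compounds shown leave open whether any change in this series gives a numerical value rather than a limit.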